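The source may report more compounds than this note shows. Statements on the series, on what has been measured and on what is new or still open speak of the compounds shown alone.

Among the compounds with values here, compound 2 `CCc1ccc(Nc2ncnc3cc(OC)c(OCCCCC(=O)Nc4ccc(S(N)(=O)=O)cc4)cc23)cc1` gives 10300 nM in a functional assay on NCI-H1975 cells (Homo sapiens) for antiproliferative activity, read by MTT assay, with a stated time of 72 h (on this read-out lower numbers stand for stronger inhibition and higher numbers for weaker inhibition), the lowest of the two numbers so far; the only neighbour, compound 1 `COc1cc2ncnc(Nc3ccc(F)c(Cl)c3)c2cc1OCCCCC(=O)Nc1ccc(S(N)(=O)=O)cc1`, gives 35600 nM in this assay, and the step of a 3.5-fold lower number from compound 1 to compound 2 (0.54 log units; beyond the scatter) came from swapping the aryl group on the amine nitrogen. Compound 3 `COc1cc2ncnc(Nc3ccccc3)c2cc1OCCCCC(=O)Nc1ccc(S(N)(=O)=O)cc1` differs from compound 2 by hydrogen in place of ethyl on an aromatic carbon. Within the data shown here, no measured step removes this ethyl directly; the one step that bears on it, a 3.5-fold lower number from compound 1 to compound 2 (0.54 log units; beyond the scatter), shows the aryl substituent matters at that size, so a step of about a 1.7-fold higher number from compound 2 to compound 3 (0.24 log units; within the scatter) toward a higher number is expected. Compound 3 is therefore estimated at 18000 nM, within 7000 nM to 45000 nM.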

Compound 3, half-maximal inhibitory concentration: 14100 nM
Compound 3: middle estimate off by 1.3-fold (0.11 log units), on the high side; the range from low to high includes it.
By their numbers in this assay, from the lowest: compounds 2 and 3 (each within the scatter of the next); then compound 1.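

Taking off the ethyl gives a 1.4-fold higher number from compound 2 to compound 3 (0.14 log units; within the scatter) in this assay and so leaves the two compounds indistinguishable on this read-out. Replacing the 3-chloro-4-fluorophenyl with plain phenyl gives a 2.5-fold lower number from compound 1 to compound 3 (0.40 log units; beyond the scatter) and so shows that the lower number seen earlier does not need the ethyl.

On these data alone, whether the chlorine or the fluorine alone accounts for the higher number of compound 1 stays open, as does whether a methoxy or an amine in the place of the ethyl would shift the number beyond the scatter. No evidence at hand gives a reason for either step.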